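Notes on the substituent on the aromatic nitrogen

A few compounds are considered here, and "the series" means these few. Any claim that something is new, unique, unknown or untested is made for them only; others in the source may bear on it.

Measured in a functional assay on HT-29 cells (Homo sapiens) for inhibition, read by luminescence and CellTiter-Glo, with a stated time of 24 h; on this read-out lower numbers stand for an effect already at smaller amounts and higher numbers for an effect only at larger amounts of compound:
- Compound 1 `CCCn1nc(C(=O)N[C@H]2COc3ccccc3N(C)C2=S)nc1Cc1ccccc1` gives 288 nM
- Compound 2 `CN1C(=S)[C@@H](NC(=O)c2nc(Cc3ccccc3)n(CC3COC3)n2)COc2ccccc21` gives 2830 nM

Compound 2 has the higher of the two numbers in this assay, and the gap to compound 1 lies beyond the scatter. The next structure is compound 3 `CN1C(=S)[C@@H](NC(=O)c2nc(Cc3ccccc3)n(C3CCNC3)n2)COc2ccccc21`, in which pyrrolidin-3-yl takes the place of (oxetan-3-yl)methyl on an aromatic nitrogen of the five-membered aromatic ring with 3 nitrogen, next to the ring atom that bears a benzyl group: pyrrolidin-3-yl in place of (oxetan-3-yl)methyl on an aromatic nitrogen.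

Going by the values given here, only one measured step bears on this change. It is a 9.8-fold higher number from compound 1 to compound 2 (0.99 log units; beyond the scatter), and it concerns the same nitrogen substituent, where oxetan-3-yl replaced ethyl on the saturated chain. Among the compounds with values here, no measured compound carries a hydrogen-bond donor in this substituent or a ring bound directly to the aromatic nitrogen, so the evidence is thin and the range must stay wide. The expectation in this assay is a small upward lean, with no step beyond the scatter as the central case.

The estimate is a 1.4-fold higher number from compound 2 to compound 3 (0.15 log units; within the scatter).

Compound 3 is expected at 4000 nM, with an estimated range from 900 nM to 18000 nM.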

Compound 3, half-maximal effective concentration: 1070 nM
Beside the measured number, compound 3's estimate is 3.7-fold (0.57 log units) above it, within the range that was stated.
By their numbers in this assay, from the lowest: compound 1; then compound 3; then compound 2.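

In this assay, the substituent on the aromatic nitrogen is not limited to upward steps from propyl: a 2.6-fold lower number from compound 2 to compound 3 (0.42 log units; beyond the scatter), with pyrrolidin-3-yl in place of (oxetan-3-yl)methyl at an equal count of 5 heavy atoms, so the two ring-bearing substituents are clearly separated from each other. The recovery is only partial, as the propyl of compound 1 still holds the lowest number of the three, with a 3.7-fold higher number from compound 1 to compound 3 (0.57 log units; beyond the scatter), a smaller rise than the one seen for the oxetane-bearing group. Nothing measured accounts for this order of the three substituents.

The step from compound 2 to compound 3 changes ring size, the ring hetero atom and the hydrogen-bond donor count together, so the share of each in the shift remains unresolved. Open as well is how this assay responds to a simple primary amine on a propyl chain, to a piperidin-4-yl group, or to a pyrrolidin-3-yl nitrogen carrying a methyl group, any of which would help separate these contributions.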